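The compounds below may be only part of what the source reports. "The series", "measured", "known", "first", "only" and "open" are said of these compounds alone.

Measured compounds:
compound 1, `CC(C)=CCc1cc(/C=C2\OC(=O)C(c3cc4c(cc3O)OC(C)(C)C(O)C4)=C2O)ccc1O`, 4200 nM
compound 2, `CC(C)=CCc1cc(C2=C(O)/C(=C/c3ccc(O)c(CC(O)C(C)(C)O)c3)OC2=O)c(O)cc1O`, 7400 nM
compound 3, `CC(C)(O)C1Cc2cc(/C=C3\OC(=O)C(c4cc5c(cc4O)OC(C)(C)C(O)C5)=C3O)ccc2O1`, 700 nM

All three values come from a functional assay on J774.1 cells (Mus musculus), read by LDH release, with a stated time of 1 h, in the presence of a further agent that is not named here; a lower number here means a stronger inhibitor, a higher number a weaker inhibitor. Compound 2 gives the highest number of the three. Compound 1 lies within the usual scatter of compound 2, so no order between those two can be read from these numbers. Compound 3 stands beyond the scatter at a clearly lower number, so of compound 2 and compound 3, compound 3 is the stronger inhibitor.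

Compound 4, `CC(C)=CCc1cc(/C=C2\OC(=O)C(c3cc(CC=C(C)C)c(O)cc3O)=C2O)ccc1O`, has not yet been measured. It differs from compound 2 in one place: 2-methylprop-1-en-1-yl in place of 1,2-dihydroxy-2-methylpropyl on a saturated chain carbon bound to an aromatic carbon. Among the measured compounds shown here, no measured pair of compounds shares exactly this change, so the direction of the step cannot be taken from a precedent. The three measured numbers sit within a moderate span. A small step is therefore expected rather than a large one. The number for compound 4 in this assay is estimated at 3500 nM, with a likely range between 1200 nM and 10000 nM. The step expected from compound 2 to compound 4 is a 2.1-fold lower number from compound 2 to compound 4 (0.33 log units; beyond the scatter), a modest move toward a lower number that may stay within the scatter.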

Compound 4, half-maximal inhibitory concentration: 3000 nM
Beside the measured number, compound 4's estimate is 1.2-fold (0.07 log units) above it; low and high end bracket the measured number.
By their numbers in this assay, from the lowest: compound 3; then compounds 4, 1 and 2 (each within the scatter of the next, the first and the last beyond it).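

In this assay, among the compounds shown here, the one comparison of compounds that differ in a single place is a 2.5-fold lower number from compound 2 to compound 4 (0.39 log units; beyond the scatter), with 3-methylbut-2-en-1-yl in place of 2,3-dihydroxy-3-methylbutyl. This shows that the position does not need the two hydroxyl groups of the leaving chain for activity, as the chain without them gives the stronger inhibitor, although the step is modest. Nothing available here explains the direction or size of this step. Going by these compounds, it remains open whether a chain with a single hydroxyl group, a longer chain, or a chain ending in an amine or a carboxylic acid would lower or raise the number. A single step also cannot show whether the same exchange would have a similar effect in other compounds.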